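Halogen swap on a thiosemicarbazone: chloro to fluoro

The source may hold more compounds than are shown below. What is called first, only, known or untested is meant among the compounds shown, and "the series" means these compounds.

Measured so far in a physicochemical assay for lipophilicity, in phosphate buffer, measured as octanol-water partition, with a stated time of 24 h; on this read-out higher numbers stand for higher lipophilicity and lower numbers for lower lipophilicity:
Compound 1, `O=[N+]([O-])c1ccc(Oc2ccc(/C=N/NC(=S)Nc3ccc(Br)cc3)cc2)cc1`, gives 5.68.
Compound 2, `Cc1ccc(Oc2ccc(/C=N/NC(=S)Nc3ccc(F)cc3)cc2)cc1`, gives 5.48.
Compound 3, `O=[N+]([O-])c1ccc(Oc2ccc(/C=N/NC(=S)Nc3ccc(Cl)cc3)cc2)cc1`, gives 5.52.

Compound 3 stands second highest of the three numbers; its nearest neighbour is compound 2, and compound 1 lies furthest away, though both gaps fall within the scatter of this assay. The unmeasured compound 4 is `O=[N+]([O-])c1ccc(Oc2ccc(/C=N/NC(=S)Nc3ccc(F)cc3)cc2)cc1`. It differs from compound 3 in one place: fluoro in place of chloro on an aromatic carbon. Going by the values given here, only one measured step bears directly on this exchange, the move from a larger halogen to a smaller one at the same place, which gave a number 0.16 log units lower from compound 1 to compound 3 (within the scatter). Compound 2 also carries fluoro, but it differs from compound 3 in a second place as well, so its value alone cannot be read as a clean comparison. Going from chloro to fluoro is expected to pull the partition coefficient down, probably by a little more than the bromo-to-chloro step did, so for compound 4 a downward change of a number 0.37 log units lower from compound 3 to compound 4 (beyond the scatter) is expected. The estimate for compound 4 in this assay is therefore 5.15, with a likely range from 4.85 to 5.45.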

Compound 4, partition coefficient: 4.89
Estimate against measurement, compound 4: 0.26 log units above; the range from low to high includes it.
By their numbers in this assay, from the lowest: compound 4; then compounds 2, 3 and 1 (each within the scatter of the next).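

In this assay, the choice of halogen on this aromatic carbon now shows a clear step: fluoro in place of chloro gives (a number 0.63 log units lower from compound 3 to compound 4 (beyond the scatter)) and fluoro in place of bromo gives (a number 0.79 log units lower from compound 1 to compound 4 (beyond the scatter)), whereas chloro in place of bromo gave only (a number 0.16 log units lower from compound 1 to compound 3 (within the scatter)). Among these three halogens, then, fluoro is the one that stands apart, and compound 4 has the lowest number of the four compounds, with its steps to all the others beyond the scatter. The halogen is also not the only place that moves this read-out, as with fluoro held constant, nitro in place of methyl gives (a number 0.59 log units lower from compound 2 to compound 4 (beyond the scatter)), while no measurement at hand explains either step.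

It remains open whether the step from methyl to nitro would have the same size with chloro or bromo as the halogen, a comparison that the compounds shown do not allow. On these data alone, it is equally open where a methoxy group, an amine or a carboxylic acid on this same aromatic carbon would fall relative to the halogens.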